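A Pyridyl Ring in Place of Chlorophenyl

The compounds below may be only part of what the source reports. "The series", "measured", "known", "first", "only" and "open" are said of these compounds alone.

Measured in an assay on cells for inhibition of sodium- and chloride-dependent glycine transporter 1 (Homo sapiens); on this read-out higher numbers stand for an effect only at larger amounts of compound and lower numbers for an effect already at smaller amounts:
- compound 1 `COc1cc(C(F)(F)F)cc(C(F)(F)F)c1C(=O)NC1(c2ccccc2)CCCN(C(=O)c2ccccc2)C1`: > 10000 nM, a limit of this assay rather than a number
- compound 2 `CN1CCCC(NC(=O)c2ccc(C(F)(F)F)cc2C#N)(c2ccccc2)C1`: > 10000 nM, likewise a limit of this assay
- compound 3 `COc1cc(C(F)(F)F)cc(SC)c1C(=O)NC1(c2ccc(Cl)cc2)CCCN(C)C1`: 28 nM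

Among the measured compounds shown here, compound 3 holds the only measured number in this assay; the other two values are limits, which is the limit of > 10000 nM in this assay, at which 2 of the 3 values shown sit. Compound 4 `COc1cc(C(F)(F)F)cc(SC)c1C(=O)NC1(c2ccc(F)cn2)CCCN(C)C1` has not been measured in this assay. It differs from compound 3 in one place: 5-fluoropyridin-2-yl in place of 4-chlorophenyl on a saturated ring carbon. For the measured compounds named here, no measured pair in this set shows what such an exchange does, so the expectation rests on compound 3 alone, and the step from compound 3 to compound 4 is estimated as a modest loss, a 2.1-fold higher number from compound 3 to compound 4 (0.33 log units; beyond the scatter), that may still fall within the usual scatter. On that basis compound 4 is expected to give about 60 nM in this assay, most likely between 15 nM and 250 nM.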

Compound 4, half-maximal effective concentration: 180 nM
Estimate against measurement, compound 4: 3.0-fold (0.48 log units) below; measured number inside the range.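

Among the compounds shown here, the exchange of 4-chlorophenyl for 5-fluoropyridin-2-yl on a saturated ring carbon gives the only reading at this position in this assay, with a 6.4-fold higher number from compound 3 to compound 4 (0.81 log units; beyond the scatter). The position therefore accepts an aromatic ring with a hetero atom and a hydrogen-bond acceptor at a real cost, yet the cost is not a full loss, as compound 4 still gives 180 nM. That number stays well clear of the limit reached by compound 1 and compound 2, which differ from compound 4 in more than one place: the limit of > 10000 nM in this assay, at which 2 of the 4 values shown sit.

The change swaps the ring carbon for nitrogen and chlorine for fluorine together, so the step cannot be assigned to either one. A 4-fluorophenyl or a 5-chloropyridin-2-yl group on the same carbon would separate the two, and a pyridin-3-yl group would speak to where the ring nitrogen can sit.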